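A few compounds are considered here, and "the series" means these few. Any claim that something is new, unique, unknown or untested is made for them only; others in the source may bear on it.

Measured in a functional assay on KM12 cells (Homo sapiens) for inhibition, read by sulforhodamine B assay, with a stated time of 48 h; on this read-out higher numbers stand for weaker inhibition and lower numbers for stronger inhibition:
compound 1 `COc1cc(-c2nn(-c3cccc(NC(=O)c4cccc(C(F)(F)F)c4)c3)cc2-c2ccncc2)ccc1Cl` gives 1660 nM
compound 2 `COc1cc(-c2nn(-c3cccc(NC(=O)Nc4cccc(C(F)(F)F)c4)c3)cc2-c2ccncc2)ccc1Cl` gives 570 nM
compound 3 `COc1cc(-c2nn(-c3cccc(NC(=O)c4ccc(Cl)c(C(F)(F)F)c4)c3)cc2-c2ccncc2)ccc1Cl` gives 2060 nM

Compound 3 stands at the high end of these three numbers; one step to it lies within the scatter, a 1.2-fold higher number from compound 1 to compound 3 (0.09 log units; within the scatter), the other beyond it, a 3.6-fold higher number from compound 2 to compound 3 (0.56 log units; beyond the scatter).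

Compound 4 `COc1cc(-c2nn(-c3cccc(NC(=O)Nc4ccc(Cl)c(C(F)(F)F)c4)c3)cc2-c2ccncc2)ccc1Cl` differs from compound 3 by (4-chloro-3-(trifluoromethyl)phenyl)amino in place of 4-chloro-3-(trifluoromethyl)phenyl on a carbonyl carbon. The same exchange of group on the carbonyl carbon has been measured once in this assay, a 2.9-fold lower number from compound 1 to compound 2 (0.46 log units; beyond the scatter), a modest step beyond the scatter; that step bears directly on the present one. A step of similar size and in the same direction is therefore expected, a 2.9-fold lower number from compound 3 to compound 4 (0.46 log units; beyond the scatter). In this assay compound 4 is estimated at 710 nM, with a likely range from 350 nM to 1450 nM.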

Compound 4, half-maximal inhibitory concentration: 1060 nM
Beside the measured number, compound 4's estimate is 1.5-fold (0.17 log units) below it; low and high end bracket the measured number.
By their numbers in this assay, from the lowest: compounds 2, 4, 1 and 3 (each within the scatter of the next, the first and the last beyond it).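

In this assay, the amino group on the carbonyl carbon of the chloro-bearing series gives a 1.9-fold lower number from compound 3 to compound 4 (0.29 log units; within the scatter), so the step beyond the scatter seen without chloro does not carry over to this pair. The change from compound 1 also stays small, a 1.6-fold lower number from compound 1 to compound 4 (0.19 log units; within the scatter). Chloro on the aromatic carbon now has a second reading, a 1.9-fold higher number from compound 2 to compound 4 (0.27 log units; within the scatter), and the two readings agree: the same change on two cores in this assay, a 1.2-fold higher number (0.09 log units; within the scatter) from compound 1 to compound 3 and a 1.9-fold higher number (0.27 log units; within the scatter) from compound 2 to compound 4, 1.5-fold (0.18 log units) apart, within the scatter of two such steps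

Still open, as far as these compounds go, is whether a methylene in place of the amino group on the carbonyl carbon would behave like either linkage. Also open, from the compounds shown here alone, is how fluoro or methoxy in place of the chloro would read.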